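The compounds below may be only part of what the source reports. "The series", "measured", "known", "first", "only" and "open" are said of these compounds alone.

Series notes. The shared core of compound 1 `COC(=O)C1=C(C)NC(=O)NC1c1ccoc1` carries a methoxycarbonyl group, and compound 1 gives 42% in an assay on membranes from HEK293 cells for displacement of a labelled ligand from adenosine receptor A2b (Homo sapiens), read by scintillation counting, with a stated time of 30 min, tested at 1 uM; a lower number here means less inhibition, a higher number more inhibition at the concentration tested (going by the name of the read-out). Compound 2 `COC(=O)C1=C(C)NC(=O)NC1c1cccs1` gives 19% in this assay, and compound 3 `COC(=O)C1=C(C)N(C)C(=O)NC1c1cccs1` gives 17% in this assay. Compound 2 stands second of the three numbers: its nearest neighbour is compound 3, and its furthest is compound 1, which lies beyond the scatter above it. The two steps recorded so far are a number 23 percentage points lower from compound 1 to compound 2 (beyond the scatter) and a number 2 percentage points lower from compound 2 to compound 3 (within the scatter).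

Compound 4 `CCNC(=O)C1=C(C)NC(=O)NC1c1cccs1` differs from compound 2 as follows: ethylamino in place of methoxy on a carbonyl carbon. Neither measured step touches this position: the step from compound 1 to compound 2 is at the saturated ring carbon and is modest, while the step from compound 2 to compound 3 is at the ring nitrogen and stays within the scatter. Among the compounds with values here, no step therefore bears directly on the change at the carbonyl carbon, and the expectation rests on compound 2 alone. The step from compound 2 to compound 4 in this assay is expected to be a number 1 percentage points higher from compound 2 to compound 4 (within the scatter), with no direction claimed beyond the scatter. Compound 4 is estimated at 20%, with a range from 2% to 42%.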

Compound 4, a percentage reported as inhibition, at one concentration (the size of the read-out at that concentration, not a potency): 1%
Compound 4: middle estimate off by 19 percentage points, on the high side; the whole stated range lies above it.
By their numbers in this assay, from the lowest: compound 4; then compounds 3 and 2 (each within the scatter of the next); then compound 1.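

Working notes on the carbonyl position. In this assay, ethylamino in place of methoxy on a carbonyl carbon gives a number 18 percentage points lower from compound 2 to compound 4 (beyond the scatter) and so shows that, with thiophen-2-yl held constant, the read-out responds to a change at this position, whereas methyl on the ring nitrogen gives only a number 2 percentage points lower from compound 2 to compound 3 (within the scatter). This single change replaces an ester with an ethylcarbamoyl group, bringing in a hydrogen-bond donor that methoxy lacks and a longer chain, and the step cannot separate the contribution of the nitrogen from that of the ethyl group. No measurement available here accounts for the drop in the read-out.

The compounds shown leave open whether ethoxy, methylamino or an unsubstituted amine on the same carbonyl carbon, or a carboxylic acid at this position, would fall with compound 2 or with compound 4. They also leave open whether ethylamino has a comparable effect when furan-3-yl takes the place of thiophen-2-yl, as in compound 1 at 42%.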